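The source may report more compounds than this note shows. Statements on the series, on what has been measured and on what is new or still open speak of the compounds shown alone.

In a physicochemical assay for lipophilicity, read by HPLC, tested at 5 mM (on this read-out higher numbers stand for higher lipophilicity and lower numbers for lower lipophilicity), the series begins with compound 1 `CCCCCCCCc1ccc(OC(C)C(=O)Cn2nnc(-c3ccccc3)n2)cc1`, a compound with an unsubstituted phenyl group on the shared core. Compound 1 gives > 8, which is a limit of the assay and not a number. Compound 2 `CCCCCCCCc1ccc(OC(C)C(=O)Cn2nnc(-c3ccc(Cl)cc3)n2)cc1` carries chloro in place of hydrogen on an aromatic carbon. Compound 2 gives > 8, which is also only a limit. Its exact position in this assay is therefore unknown.

The next compound, compound 3 `CCCCCCCCc1ccc(OC(C)C(=O)Cn2nnc(-c3ccc(C(=O)OC)cc3)n2)cc1`, is reached from compound 2 by one change: methoxycarbonyl in place of chloro on an aromatic carbon. In words, methoxycarbonyl stands in place of chloro on an aromatic carbon, para to a large group.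

Going by the values given here, only one measured step bears on this change, a step that the two limits leave unreadable from compound 1 to compound 2, and it involves a different substitution. No size or direction can be carried over from it because the limit of > 8 in this assay, at which 2 of the 2 values shown sit, is all that the measurements provide. The expected result is therefore a step that the limit leaves unreadable from compound 2 to compound 3, a loosely held estimate that stays close to the limit. For compound 3, the estimated value in this assay is 8.2, with an expected range from 7.6 to 8.8.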

Compound 3, partition coefficient: > 8
Compound 3: only a limit was reported; the forecaster's own chance of this, stated with the estimate: 65%; the middle value is on the limit's open side.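

In this assay compound 3 gives > 8, which is a limit and not a number. No new step can be read, either from compound 1 to compound 3 or from compound 2 to compound 3. The compounds shown leave open where compound 1, compound 2 and compound 3 actually stand relative to one another: the limit of > 8 in this assay, at which 3 of the 3 values shown sit.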